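Trading a benzyl sulfide for an ethynyl sulfide

A few compounds are considered here, and "the series" means these few. Any claim that something is new, unique, unknown or untested is made for them only; others in the source may bear on it.

The measured compounds and their numbers in a toxicity assay on GES1 cells (Homo sapiens) for inhibition, read by MTT assay, with a stated time of 72 h; on this read-out lower numbers stand for stronger inhibition and higher numbers for weaker inhibition:
Compound 1, `Cc1cc(N2CC[C@@H](C)[C@@H](N(C)c3ncnc4[nH]ccc34)C2)n2nc(SCc3ccc(F)cc3)nc2n1`, gives 12300 nM.
Compound 2, `Cc1cc(N2CC[C@@H](C)[C@@H](N(C)c3ncnc4[nH]ccc34)C2)n2nc(SCC3CCCCC3)nc2n1`, gives 98200 nM.
Compound 3, `Cc1cc(N2CC[C@@H](C)[C@@H](N(C)c3ncnc4[nH]ccc34)C2)n2nc(SCc3ccc(C(F)(F)F)cc3)nc2n1`, gives 17300 nM.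

Compound 1 holds the lowest number of the three; compound 3 sits nearest to it, within the scatter, while compound 2 lies furthest away. Compound 4, `C#CSc1nc2nc(C)cc(N3CC[C@@H](C)[C@@H](N(C)c4ncnc5[nH]ccc45)C3)n2n1`, differs from compound 1 as follows: ethynyl in place of 4-fluorobenzyl on a sulfur. Among the compounds with values here, no measured pair shows this exact change. The nearest guide is an 8.0-fold higher number from compound 1 to compound 2 (0.90 log units; beyond the scatter), where the aromatic ring gave way to a saturated ring and the number rose beyond the scatter. By contrast, a 1.4-fold higher number from compound 1 to compound 3 (0.15 log units; within the scatter) stayed within the scatter, so swapping one aromatic substituent for another left this assay unmoved. Removing the ring altogether in favour of a two-carbon ethynyl group goes further than either step, so a rise in the number, in the direction seen for compound 2, is expected, with wide uncertainty. Compound 4 is therefore estimated at 30000 nM, with a range from 8000 nM to 120000 nM. That estimate corresponds to an expected step of a 2.4-fold higher number from compound 1 to compound 4 (0.39 log units; beyond the scatter).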

Compound 4, half-maximal inhibitory concentration: > 100000 nM
Compound 4: only a limit was reported (the forecaster's own chance of this, stated with the estimate: 20%); at least 3.3-fold (0.52 log units) between middle value and limit.
By their numbers in this assay, from the lowest: compounds 1 and 3 (each within the scatter of the next); then compound 2. At a limit, above all of these: compound 4.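

In this assay compound 4 returns only a limit, not a number: the limit of > 100000 nM in this assay, at which 1 of the 4 values shown sits. On this sulfur, ethynyl gives an at least 8.1-fold higher number from compound 1 to compound 4 (0.91 log units; beyond the scatter) and an at least 5.7-fold higher number from compound 3 to compound 4 (0.76 log units; beyond the scatter), so among the four compounds only the two with a substituted benzyl group keep the low numbers. The cyclohexylmethyl group also stands away from them, with an 8.0-fold higher number from compound 1 to compound 2 (0.90 log units; beyond the scatter) and a 5.7-fold lower number from compound 2 to compound 3 (0.75 log units; beyond the scatter). Ethynyl in place of cyclohexylmethyl gives an at least 1.0-fold higher number from compound 2 to compound 4 (0.00 log units; that floor lies within the scatter), so a saturated ring and no ring at all cannot be ranked in this assay.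

The compounds shown leave open how much of the benzyl group the low numbers need. An unsubstituted phenyl on the sulfur, or a longer chain ending in an amine, would test that.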